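The source may report more compounds than this note shows. Statements on the series, on what has been measured and on what is new or still open speak of the compounds shown alone.

In an ADME assay on BJ cells (Homo sapiens), read by MTT assay, with a stated time of 72 h (on this read-out lower numbers stand for stronger inhibition and higher numbers for weaker inhibition), compound 2 `Cc1ncnc2c1c(I)cn2[C@@H]1O[C@H](CO)[C@@H](O)[C@H]1O` gives only a limit of > 100000 nM rather than a number. Compound 3 `Cc1nc(N)c2c(-c3ccco3)cn([C@@H]3O[C@H](CO)[C@@H](O)[C@H]3O)c2n1` also gives only a limit, > 100000 nM. Compound 1 `COc1ncnc2c1c(-c1ccsc1)cn2[C@@H]1O[C@H](CO)[C@@H](O)[C@H]1O`, which carries a thiophen-3-yl group and a methoxy group on the shared core, gives 64300 nM in this assay. Two of the three values thus share (the limit of > 100000 nM in this assay, at which 2 of the 3 values shown sit). Compound 4 `Cc1ncnc2c1c(-c1cccs1)cn2[C@@H]1O[C@H](CO)[C@@H](O)[C@H]1O` differs from compound 2 in one place: thiophen-2-yl in place of iodo on an aromatic carbon. Among the measured compounds shown here, no measured pair shows the effect of this change directly. Compound 1, with its own thiophene ring, gives 64300 nM. On that basis the step of an at least 1.2-fold lower number from compound 2 to compound 4 (0.09 log units; that floor lies within the scatter) is expected to be small, within the usual scatter or a little beyond it. Compound 4 is therefore estimated at 80000 nM, in the range 30000 nM to 200000 nM, with a real chance that only a limit is reported.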

Compound 4, half-maximal inhibitory concentration: > 100000 nM
Compound 4: a limit, no number; the forecaster's own chance of this, stated with the estimate: 50%; middle value at least 1.2-fold (0.09 log units) away from the limit.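

Among the compounds shown here, compound 2 and compound 4 both give only a limit in this assay, so no step between them can be read. The compounds shown leave open how far thiophen-2-yl in place of iodo shifts the value.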